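The source may report more compounds than this note shows. Statements on the series, on what has been measured and on what is new or still open speak of the compounds shown alone.

In a functional assay on MCF7 cells (Homo sapiens) for antiproliferative activity, read by MTT assay, with a stated time of 72 h (on this read-out lower numbers stand for stronger inhibition and higher numbers for weaker inhibition), compound 1 (`O=C1C=C(N2CCN(c3ccccc3Cl)CC2)C(=O)c2ccccc21`) gives 10300 nM, compound 2 (`O=C1C=C(N2CCN(c3ccccc3Cl)CC2)C(=O)c2c(O)cccc21`) gives 23800 nM and compound 3 (`O=C1C=C(N2CCC(c3ccccc3)CC2)C(=O)c2c(O)cccc21`) gives 8800 nM. Compound 3 thus stands level with compound 1, within the scatter, and at a clearly lower number than compound 2. Compound 4 (`O=C1C=C(N2CCC(c3ccc(Cl)cc3)CC2)C(=O)c2c(O)cccc21`) differs from compound 3 by chloro in place of hydrogen on an aromatic carbon, phenyl to 4-chlorophenyl. Among the compounds with values here, the one measured step in a single place, a 2.3-fold higher number from compound 1 to compound 2 (0.36 log units; beyond the scatter), is modest and brings in hydroxy rather than chloro, so it offers only a rough gauge of size, and no shift beyond the scatter is expected in either direction. The expected step is a 1.2-fold lower number from compound 3 to compound 4 (0.07 log units; within the scatter). For compound 4 the estimated value is 7500 nM, with an expected range of 3500 nM to 16000 nM.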

Compound 4, half-maximal inhibitory concentration: 20500 nM
Beside the measured number, compound 4's estimate is 2.7-fold (0.44 log units) below it; measured number above the stated range.
By their numbers in this assay, from the lowest: compounds 3, 1, 4 and 2 (each within the scatter of the next, the first and the last beyond it).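

In this assay, chloro in place of hydrogen on the aromatic carbon para to a large group gives a 2.3-fold higher number from compound 3 to compound 4 (0.37 log units; beyond the scatter), a modest rise. This is the only step shown on this ring, and it shows that the position is sensitive to a single added chlorine atom, with the number moving upward. Nothing available here accounts for the rise. From the compounds shown here alone, whether it is specific to chloro stays open, since one step cannot tell. Fluoro, methoxy or an amine at the same place would show whether other groups there also raise the number.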